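Trimming the Chain on the Aromatic Nitrogen

The source may hold more compounds than are shown below. What is called first, only, known or untested is meant among the compounds shown, and "the series" means these compounds.

Measured so far:
compound 1, `CN1CCN(CCNC(=O)n2c(=O)n(C)c3ccccc32)CC1`, 0.42
compound 2, `CCCCn1c(=O)n(C(=O)NCCN2CCN(C)CC2)c2ccccc21`, < 0.3

Compound 1, `CN1CCN(CCNC(=O)n2c(=O)n(C)c3ccccc32)CC1`, gives 0.42 in a functional assay for agonist activity at 5-hydroxytryptamine receptor 4 (Cavia porcellus) (a higher number here means a larger maximal response, a lower number a smaller maximal response), so its largest response falls well short of the reference agonist. Compound 2 is `CCCCn1c(=O)n(C(=O)NCCN2CCN(C)CC2)c2ccccc21`. In this assay compound 2 gives < 0.3, which is a limit of the assay rather than a number. For the measured compounds named here, the only measured step runs a number at least 0.12 lower from compound 1 to compound 2 (beyond the scatter), and its true size is unknown because compound 2 sits at the limit of < 0.3 in this assay, at which 1 of the 2 values shown sits.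

Compound 3, `CCCn1c(=O)n(C(=O)NCCN2CCN(C)CC2)c2ccccc21`, is drawn from compound 2 by a single change: hydrogen in place of methyl on a saturated chain carbon, three bonds along the chain from an aromatic nitrogen. Most of the chain that was added in the step from compound 1 to compound 2 stays in place, so compound 3 is not expected to recover the response of compound 1, and the step of a number no lower from compound 2 to compound 3 (the limit leaves the size open) is expected to be no more than modest. Compound 3 is therefore expected to give about 0.3 in this assay, with a range from 0.15 to 0.45, and a fair chance that only a limit is reported.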

Compound 3, intrinsic activity: the largest response reached, as a fraction of the reference agonist's: 0.48
The estimate for compound 3 lay 0.18 below the measured number; the whole stated range lies below it.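

In this assay, the response does not simply shrink as the chain on the aromatic nitrogen grows: going from methyl to propyl, the step runs a number 0.060 higher from compound 1 to compound 3 (within the scatter), so the two compounds cannot be told apart. The loss seen with the butyl chain of compound 2 therefore does not extend to propyl, and the change from butyl to propyl, a single carbon, is enough to separate the two, with a step that runs a number at least 0.18 higher from compound 2 to compound 3 (beyond the scatter). The full size of that step stays unknown because compound 2 is reported only as a limit of the assay: the limit of < 0.3 in this assay, at which 1 of the 3 values shown sits.

With only methyl, propyl and butyl shown on this nitrogen, the compounds cannot say whether the response stays level through an ethyl chain or how sharply it falls away once the chain reaches butyl. A pentyl chain, a branched isopropyl group or a propyl chain ending in an amine or a carboxylic acid would test whether chain length alone decides the outcome or whether what the chain carries also matters.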